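Notes: vinyl in place of ethyl in compound 1

The source may hold more compounds than are shown below. What is called first, only, known or untested is meant among the compounds shown, and "the series" means these compounds.

Measured so far:
- compound 1 (`CCOC(=O)c1csc2nc(-c3ccc(NC(=O)CC)cc3)cn12`) gives (9520 nM)
- compound 2 (`CCOC(=O)c1csc2nc(-c3cccc(NC(=O)CC)c3)cn12`) gives (> 20000 nM), a limit of the assay and not a number
- compound 3 (`CCOC(=O)c1csc2nc(-c3ccc(NC(=O)c4ccco4)cc3)cn12`) gives (9920 nM)

Among the compounds with values here, in a functional assay on MV4-11 cells (Homo sapiens) for cytotoxicity, read by MTT assay, with a stated time of 72 h (a lower number here means a stronger inhibitor, a higher number a weaker inhibitor), compound 1 stands at (9520 nM) alongside compound 3, the two lying within the scatter of each other, and these are the only two numbers available. Within the data shown here, compound 2 is known only as a limit and offers no step here.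

Compound 4 (`C=CC(=O)Nc1ccc(-c2cn3c(C(=O)OCC)csc3n2)cc1`) keeps the core of compound 1 and has vinyl in place of ethyl on a carbonyl carbon, that is, propanoylamino to (vinylcarbonyl)amino. Among the measured compounds shown here, one measured step bears on this change: furan-2-yl in place of ethyl on a carbonyl carbon (a 1.0-fold higher number from compound 1 to compound 3 (0.02 log units; within the scatter)), which stays within the scatter. On the strength of that step, compound 4 is expected to show no step beyond the scatter in this assay in either direction. A single step is thin support, so the range is kept wide. The estimated step is (a 1.4-fold lower number from compound 1 to compound 4 (0.13 log units; within the scatter)) and no more than that is expected. For compound 4 the expected value is (7000 nM), with an estimated range from (2500 nM) to (18000 nM).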

Compound 4, half-maximal inhibitory concentration: 2930 nM
Estimate against measurement, compound 4: 2.4-fold (0.38 log units) above; low and high end bracket the measured number.
By their numbers in this assay, from the lowest: compound 4; then compounds 1 and 3 (each within the scatter of the next). At a limit, above all of these: compound 2.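

In this assay, the carbonyl carbon on the amide-type nitrogen proves responsive to change: vinyl in place of ethyl gives a step beyond the scatter, though a modest one (a 3.2-fold lower number from compound 1 to compound 4 (0.51 log units; beyond the scatter)). Compound 1 and compound 3 had suggested little sensitivity there, with ethyl and furan-2-yl within the scatter of each other, but vinyl also separates from furan-2-yl (a 3.4-fold lower number from compound 3 to compound 4 (0.53 log units; beyond the scatter)), so among these three groups the lower number goes with vinyl alone and not with the loss of ethyl as such. Nothing at hand accounts for this step.

Whether the lower number follows the double bond itself stays open, since the compounds shown include no longer chain carrying that double bond, no alkyne on the carbonyl carbon and no such chain ending in an amine. Also open, on these data alone, is whether the vinyl step holds when the ethyl ester on the shared core gives way to a carboxylic acid or a primary amide, as all four compounds keep that ester.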